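The compounds below may be only part of what the source reports. "The series", "measured", "known", "first", "only" and "open" are said of these compounds alone.

Working notes on the hydrazone series.

In an assay on isolated protein for inhibition of Maltase-glucoamylase (Homo sapiens), with a stated time of 15 min (on this read-out lower numbers stand for stronger inhibition and higher numbers for weaker inhibition), compound 1 `COc1ccc(O)c(/C=N/NC(=O)c2ccc(-c3nc4ccccc4s3)cc2)c1` gives 6500 nM and compound 2 `O=C(N/N=C/c1ccc(O)c(O)c1)c1ccc(-c2nc3ccccc3s2)cc1` gives 15100 nM. Among the compounds with values here, the one single-point step measured so far, a 2.3-fold higher number from compound 1 to compound 2 (0.37 log units; beyond the scatter), shows that swapping the hydroxy and methoxy substitution pattern on the aryl carbon with the double bond to nitrogen moves the read-out only modestly, and both compounds stay in the same broad range of weak inhibition.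

Within the data shown here, compound 3 `COC(=O)c1ccc(/C=N/NC(=O)c2ccc(-c3nc4ccccc4s3)cc2)cc1` stands apart: in this assay compound 3 is reported as "not active" (no number reported), so no single number is available for it, and it therefore anchors no numerical step of its own.

Compound 4 `COc1ccc(/C=N/NC(=O)c2ccc(-c3nc4ccccc4s3)cc2)cc1O` is the next member to be run. Relative to compound 3 the change is 3-hydroxy-4-methoxyphenyl in place of 4-(methoxycarbonyl)phenyl on a carbon with a double bond to nitrogen. Among the measured compounds shown here, no measured step covers this particular exchange; the nearest information is the step from compound 1 to compound 2, which shows that a hydroxy/methoxy-bearing aryl group on this carbon sits in the measurable, weakly inhibiting range, while compound 3 with its ester-bearing aryl group gave no number at all. On this basis compound 4 is expected to return to measurable inhibition in this assay, near the values of compound 1 and compound 2, and the estimate for compound 4 is 10000 nM, with a range of 3500 nM to 30000 nM.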

Compound 4, half-maximal inhibitory concentration: "not active" (no number reported)
Compound 4 has no reported number here; the estimate stays without a comparison.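

In this assay compound 3 and compound 4 are both reported as "not active" with no number, so no step can be read between them. No measured evidence bears on this result.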